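Replacing the amide aryl group on a shared core

The source may report more compounds than this note shows. Statements on the series, on what has been measured and on what is new or still open speak of the compounds shown alone.

Measured so far:
compound 1 `O=C(Nc1ccc(Cl)c(-c2nnc3c(Cl)cccn23)c1)c1ccc(F)cc1Cl` gives 75000 nM in a functional assay on MDA-MB-231 cells (Homo sapiens) for antiproliferative activity, read by MTT assay, with stated times of 72 h and 4 h; on this read-out higher numbers stand for weaker inhibition and lower numbers for stronger inhibition
compound 2 `Cc1nc(C(=O)Nc2ccc(Cl)c(-c3nnc4c(Cl)cccn34)c2)cs1` gives > 100000 nM in this assay, a limit of the assay and not a number
compound 3 `Cc1cc(Cl)ccc1C(=O)Nc1ccc(Cl)c(-c2nnc3c(Cl)cccn23)c1` gives > 100000 nM in this assay, a limit of the assay and not a number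

Compound 1 stands alone as the only number shown; the other two values are limits. Compound 4 `CS(=O)(=O)c1cccc(C(=O)Nc2ccc(Cl)c(-c3nnc4c(Cl)cccn34)c2)c1` has not yet been measured; it differs from compound 1 by 3-(methylsulfonyl)phenyl in place of 2-chloro-4-fluorophenyl on a carbonyl carbon. Within the data shown here, the steps that bear on this change are an at least 1.3-fold higher number from compound 1 to compound 2 (0.12 log units; that floor lies within the scatter) and an at least 1.3-fold higher number from compound 1 to compound 3 (0.12 log units; that floor lies within the scatter), both of which ran to the limit (the limit of > 100000 nM in this assay, at which 2 of the 3 values shown sit). Between compound 2 and compound 3 the two limits leave the step unreadable. Every replacement of the 2-chloro-4-fluorophenyl so far has returned only a limit, so a weaker or unreadable result is expected for this change as well. Compound 4 is expected to give about 120000 nM, in the range 50000 nM to 300000 nM, which would mean an estimated step of a 1.6-fold higher number from compound 1 to compound 4 (0.20 log units; within the scatter).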

Compound 4, half-maximal inhibitory concentration: > 100000 nM
Compound 4: a limit, no number; the forecaster's own chance of this, stated with the estimate: 60%; the middle value does not contradict the limit.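

In this assay, the 3-(methylsulfonyl)phenyl group, the first replacement here with hydrogen-bond acceptors, also ends in a limit and not a number, with an at least 1.3-fold higher number from compound 1 to compound 4 (0.12 log units; that floor lies within the scatter). The steps among compound 2, compound 3 and compound 4 cannot be read. Compound 1 remains the only compound with a number, as a phenyl, now with a methylsulfonyl group, joins the earlier replacements at the limit: the limit of > 100000 nM in this assay, at which 3 of the 4 values shown sit.

From the compounds shown here alone, the true values of compound 2, compound 3 and compound 4 stay open. Also open, going by these compounds, is whether a phenyl carrying a carboxylic acid or an amine on this carbonyl carbon would give a number at all.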